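A Third Methoxy Group Joins an Inactive Pair

A few compounds are considered here, and "the series" means these few. Any claim that something is new, unique, unknown or untested is made for them only; others in the source may bear on it.

Of the compounds shown here, two built on one shared core have been tested in a functional assay on HCT-116 cells (Homo sapiens) for cytotoxicity, read by MTT assay, with a stated time of 72 h; on this read-out lower numbers stand for stronger inhibition and higher numbers for weaker inhibition. In this assay compound 1 `COc1cc(Nc2nc3ccccc3nc2S(=O)(=O)c2ccccc2)cc(OC)c1OC` gives > 50000 nM, which is a limit of the assay rather than a number. Compound 2 `COc1cc(Nc2nc3ccccc3nc2S(=O)(=O)c2ccc(Br)cc2)cc(OC)c1` likewise gives > 50000 nM in this assay, again a limit and not a measured number. Compound 2 therefore stands where every value shown stands, at the limit of > 50000 nM in this assay, at which 2 of the 2 values shown sit, with nothing to separate it from compound 1.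

Compound 3 `COc1cc(Nc2nc3ccccc3nc2S(=O)(=O)c2ccc(Br)cc2)cc(OC)c1OC` keeps the bromine-bearing part of compound 2 and differs from it by methoxy in place of hydrogen on an aromatic carbon. The same three-methoxy pattern is already present in compound 1, which also sits at the limit, so the change does not point toward a gain in cytotoxicity on the evidence at hand.

The expected step from compound 2 to compound 3 in this assay is a step that the limit leaves unreadable from compound 2 to compound 3, that is none beyond the scatter. Compound 3 is estimated to give about 60000 nM in this assay, within a range from 20000 nM to 200000 nM, most likely reported again only as a limit.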

Compound 3, half-maximal inhibitory concentration: 13000 nM
Compound 3: the middle estimate sits 4.6-fold (0.66 log units) above what was measured, and the stated range ends above it.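

In this assay, compound 3 is the only one of the three compounds shown to give a number rather than a limit, so the aromatic carbon ortho to two methoxy groups is a place where a change can register in this series. Methoxy in place of hydrogen at that carbon gives an at least 3.8-fold lower number from compound 2 to compound 3 (0.58 log units; beyond the scatter), while bromo in place of hydrogen gives an at least 3.8-fold lower number from compound 1 to compound 3 (0.58 log units; beyond the scatter); the third methoxy group shows a measurable effect only with the bromine present, and the bromine only with the third methoxy group present. Both steps can be read only as minimum sizes because their starting compounds sit at a limit: the limit of > 50000 nM in this assay, at which 2 of the 3 values shown sit.

As far as these compounds go, the true size of each step therefore stays open, as does whether methoxy itself matters or a hydroxyl group or an amine at the same carbon would serve equally well. From the compounds shown here alone, it is also open whether the bromine is specifically needed or chlorine or a nitrile could take its place alongside the three methoxy groups.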